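The source may hold more compounds than are shown below. What is called first, only, known or untested is meant among the compounds shown, and "the series" means these compounds.

Measured compounds:
Compound 1 `[N-]=[N+]=NCc1nnc(-c2cc(S(N)(=O)=O)c(SCc3ccccc3)cc2Cl)o1` — 55000 nM
Compound 2 `NS(=O)(=O)c1cc(-c2nnc(CNC(=O)c3ccccc3)o2)c(Cl)cc1SCc1ccccc1` — 66000 nM
Compound 3 `NS(=O)(=O)c1cc(-c2nnc(CNS(=O)(=O)c3ccc(Cl)cc3)o2)c(Cl)cc1SCc1ccccc1` — 30000 nM

In a functional assay on MCF7 cells (Homo sapiens) for cytotoxicity, read by MTT assay, with a stated time of 72 h (a lower number here means a stronger inhibitor, a higher number a weaker inhibitor), compound 3 gives the lowest of the three numbers, although compound 1 sits within the scatter of it, while the step of a 2.2-fold lower number from compound 2 to compound 3 (0.34 log units; beyond the scatter) is the only one beyond the scatter. The three measured compounds share one core and differ only in the group on the carbon of the five-membered ring: a 1.2-fold higher number from compound 1 to compound 2 (0.08 log units; within the scatter) and a 1.8-fold lower number from compound 1 to compound 3 (0.26 log units; within the scatter) both stay within the scatter, so every substituent tried so far has left the number in the same weak region.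

Compound 4 `NS(=O)(=O)c1cc(-c2nnc(/C=C/c3ccc(Cl)cc3)o2)c(Cl)cc1SCc1ccccc1` departs further from that pattern: 2-(4-chlorophenyl)ethenyl in place of (((4-chlorophenyl)sulfonyl)amino)methyl on an aromatic carbon. Within the data shown here, no measured pair exchanges a linker of this sort, so the three steps only show that changes at this position have so far moved the number modestly at most. On that basis the step of a 1.2-fold higher number from compound 3 to compound 4 (0.07 log units; within the scatter) is expected to stay close to the measured spread, with no strong reason to expect a large shift in either direction. Compound 4 is therefore estimated at 35000 nM in this assay, with a range from 12000 nM to 100000 nM.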

Compound 4, half-maximal inhibitory concentration: 11000 nM
The estimate for compound 4 lay 3.2-fold (0.50 log units) above the measured number; measured number outside the range, below it.
By their numbers in this assay, from the lowest: compound 4; then compounds 3, 1 and 2 (each within the scatter of the next, the first and the last beyond it).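

In this assay, among these compounds, 2-(4-chlorophenyl)ethenyl is the first group at this aromatic carbon to separate a compound from all the others beyond the scatter, with a 2.7-fold lower number from compound 3 to compound 4 (0.44 log units; beyond the scatter), a 6.0-fold lower number from compound 2 to compound 4 (0.78 log units; beyond the scatter) and a 5.0-fold lower number from compound 1 to compound 4 (0.70 log units; beyond the scatter), so compound 4 is the strongest of the four, although each step is still modest. Compound 3 and compound 4 both carry the 4-chlorophenyl ring, so the step between them alters the connection from that ring to the shared core: the saturated chain carbon, the amine nitrogen and the sulfonyl group leave, the hydrogen-bond donor and acceptors leave with them, and an ethenyl link enters. Nothing available here explains why this exchange lowers the number.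

Since these parts change together, the compounds shown do not separate the contribution of the double bond from that of losing the sulfonyl and amine portion. They also leave open whether a saturated ethyl link in place of the ethenyl link, or an unsubstituted phenyl, a fluorine or a methoxy group in place of the 4-chlorophenyl ring, would keep the number at this level.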